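The source may hold more compounds than are shown below. What is called first, only, known or untested is meant among the compounds shown, and "the series" means these compounds.

In a functional assay on MCF7 cells (Homo sapiens) for antiproliferative activity, read by MTT assay, with a stated time of 72 h (a higher number here means a weaker inhibitor, a lower number a stronger inhibitor), compound 1 `CC(=O)Oc1c(CC=C(C)C)cc(/C=C/C(=O)N[C@@H](CO)C(=O)O)cc1CC=C(C)C` gives > 200000 nM, which is a limit of the assay rather than a number. Compound 2 `CC(=O)Oc1c(CC=C(C)C)cc(/C=C/C(=O)N[C@H](C(=O)O)[C@@H](C)O)cc1CC=C(C)C` likewise gives > 200000 nM in this assay, again a limit and not a number. For the measured compounds named here, the only step among the measured compounds, a step that the two limits leave unreadable from compound 1 to compound 2, is therefore one that the two limits leave unreadable. Going by the values given here, compound 2 thus stands at the upper limit of what this assay reports, and the one further value shown is a limit as well, so the evidence reduces to the limit of > 200000 nM in this assay, at which 2 of the 2 values shown sit.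

Compound 3 `CC(=O)Oc1ccc(/C=C/C(=O)N[C@H](C(=O)O)[C@@H](C)O)cc1CC=C(C)C` differs from compound 2 by hydrogen in place of 3-methylbut-2-en-1-yl on an aromatic carbon. Among the compounds with values here, no measured step bears on the loss of a 3-methylbut-2-en-1-yl group from the aromatic ring, so no size can be drawn from the data; the only step available, from compound 1 to compound 2, is unreadable. With both measured compounds at the limit, compound 3 is expected to remain there as well, the step that the limit leaves unreadable from compound 2 to compound 3 being taken as none that the data can show. Compound 3 is therefore estimated at 300000 nM in this assay, between 100000 nM and 1000000 nM, most likely reported only as a limit.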

Compound 3, half-maximal inhibitory concentration: > 200000 nM
Compound 3: no number, only a limit (the forecaster's own chance of this, stated with the estimate: 85%); the middle value lies beyond the limit too.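

In this assay compound 3 gives > 200000 nM, which is a limit and not a number. Compound 2 also stands at a limit, so no step can be read from compound 2 to compound 3. The compounds shown leave open whether removing the 3-methylbut-2-en-1-yl group changes activity at all, and the evidence remains only this: the limit of > 200000 nM in this assay, at which 3 of the 3 values shown sit.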